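This account rests on a few compounds, and the source may have more. Where it says the series, first, only, none or still open, it means among the compounds named here.

Compound 1 `COc1cc(-c2nn(-c3cccc(NC(=O)Nc4ccc(Cl)c(Cl)c4)c3)cc2-c2ccncc2)ccc1Cl` — in a functional assay on OVCAR-3 cells (Homo sapiens) for inhibition, read by sulforhodamine B assay, with a stated time of 48 h (a lower number here means a stronger inhibitor of growth, a higher number a weaker inhibitor of growth), compound 1 gives 2270 nM.
Compound 2 `O=C(Nc1cccc(-n2cc(-c3ccncc3)c(-c3ccc(Cl)c(O)c3)n2)c1)Nc1ccc(Cl)c(Cl)c1` — compound 2 gives 3150 nM.

Going by the values given here, on these two numbers compound 2 stands together with compound 1: the only measured step, a 1.4-fold higher number from compound 1 to compound 2 (0.14 log units; within the scatter), is within the scatter, so neither compound can be called the stronger. Compound 3 `O=C(Nc1cccc(-n2cc(-c3ccncc3)c(-c3ccc(Cl)c(O)c3)n2)c1)Nc1ccc(Cl)c(C(F)(F)F)c1` differs from compound 2 by trifluoromethyl in place of chloro on an aromatic carbon. Among the compounds with values here, no measured step touches this part of the molecule, as a 1.4-fold higher number from compound 1 to compound 2 (0.14 log units; within the scatter) alters a different place, so nothing here points to a step beyond the scatter. Compound 3 is therefore expected near 3000 nM, with a range of 1000 nM to 9000 nM, meaning an estimated step of a 1.1-fold lower number from compound 2 to compound 3 (0.02 log units; within the scatter).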

Compound 3, concentration for total growth inhibition: 2090 nM
Estimate against measurement, compound 3: 1.4-fold (0.16 log units) above, within the range that was stated.
By their numbers in this assay, from the lowest: compounds 3, 1 and 2 (each within the scatter of the next).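

Going by these compounds alone, this is the first measured change on the 3,4-dichlorophenyl ring, at the carbon ortho to a chloro group and meta to a large group. In this assay, trifluoromethyl in place of chloro gives a 1.5-fold lower number from compound 2 to compound 3 (0.18 log units; within the scatter), so four heavy atoms can stand where one stood and the two compounds still cannot be told apart. Nothing available explains this result.

As far as these compounds go, whether an amine, a nitrile or a carboxylic acid at this position would stay level with compound 2 remains open. So does whether the same swap would read alike in compound 1, with methyl on its oxygen.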